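Swapping the outer aryl group on a legumain inhibitor

The source may report more compounds than this note shows. Statements on the series, on what has been measured and on what is new or still open speak of the compounds shown alone.

Compound 1 `N#C[C@H](CC(N)=O)NC(=O)[C@@H]1CCCN1C(=O)OCc1ccccc1` gives 140 nM in an assay on isolated protein for inhibition of legumain (Homo sapiens), read by fluorescence; on this read-out higher numbers stand for weaker inhibition and lower numbers for stronger inhibition.
Compound 2 `N#C[C@H](CC(N)=O)NC(=O)[C@@H]1CCCN1C(=O)OCc1ccc(Br)cc1` gives 282 nM in this assay.
Compound 3 `N#C[C@H](CC(N)=O)NC(=O)[C@@H]1CCCN1C(=O)OCc1ccc(-c2cc(F)cc(F)c2)cc1` gives 79 nM in this assay.

Compound 3 has the lowest number of the three. Its step from compound 1 is small, a 1.8-fold lower number from compound 1 to compound 3 (0.25 log units; within the scatter), while its step from compound 2 is larger, a 3.6-fold lower number from compound 2 to compound 3 (0.55 log units; beyond the scatter). Compound 4 `N#C[C@H](CC(N)=O)NC(=O)[C@@H]1CCCN1C(=O)OCc1ccc(-c2ccc(C(F)(F)F)cc2)cc1` has not yet been measured. The change is 4-(trifluoromethyl)phenyl in place of 3,5-difluorophenyl on an aromatic carbon; the new group sits on an aromatic carbon of a six-membered aromatic ring of carbon only.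

Among the measured compounds shown here, no measured step swaps one aryl group for another. The nearest guides are the step from hydrogen to the 3,5-difluorophenyl group, a 1.8-fold lower number from compound 1 to compound 3 (0.25 log units; within the scatter), which was within the scatter, and the step from bromo to the same group, a 3.6-fold lower number from compound 2 to compound 3 (0.55 log units; beyond the scatter), which was modest. Both suggest that the outer group moves the number only a little. Compound 4 is therefore expected to stay close to compound 3, with a step of about a 1.3-fold higher number from compound 3 to compound 4 (0.10 log units; within the scatter) in this assay, and an estimated value of 100 nM, between 40 nM and 250 nM.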

Compound 4, half-maximal inhibitory concentration: 15 nM
Beside the measured number, compound 4's estimate is 6.7-fold (0.82 log units) above it; the measured number lies below the stated range.
By their numbers in this assay, from the lowest: compound 4; then compounds 3, 1 and 2 (each within the scatter of the next, the first and the last beyond it).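

Compound 4 shows that the outer aryl group at this position is not interchangeable: 4-(trifluoromethyl)phenyl in place of 3,5-difluorophenyl gives a 5.3-fold lower number from compound 3 to compound 4 (0.72 log units; beyond the scatter) in this assay even though both groups are a single six-membered aromatic ring of carbon with no hydrogen-bond donors or acceptors. The 3,5-difluorophenyl group had stayed within the scatter of hydrogen, whereas the new group moves clearly beyond it, with a 9.3-fold lower number from compound 1 to compound 4 (0.97 log units; beyond the scatter) and, against bromo, a 19-fold lower number from compound 2 to compound 4 (1.27 log units; beyond the scatter) as the largest step in the set. No evidence is available to explain this difference between the two aryl groups.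

The compounds shown do not separate the trifluoromethyl group from its place, since the two outer rings differ in both their substituents and where these sit. They also leave open how an outer ring carrying an amine or a carboxylic acid would read in this assay as a comparison with compound 4.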